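Amide nitrogen substituents: from isobutyl to propyl

This account rests on a few compounds, and the source may have more. Where it says the series, first, only, none or still open, it means among the compounds named here.

Measured in an assay on HEK293 cells for positive allosteric modulation of metabotropic glutamate receptor 2 (Rattus norvegicus), read by thallium flux; a higher number here means that more compound is needed for the effect, a lower number that less compound is needed:

compound 1, `O=C(O)c1cc(-c2cccc(COc3ccc4c(c3)CN(CC3CC3)C4=O)c2)ccc1Cl`, 80 nM
compound 2, `O=C(O)c1cc(-c2cccc(COc3ccc4c(c3)CN(C3CCC3)C4=O)c2)ccc1Cl`, 90 nM
compound 3, `CC(C)CN1Cc2cc(OCc3cccc(-c4ccc(Cl)c(C(=O)O)c4)c3)ccc2C1=O`, 100 nM

Of the three numbers, that of compound 3 is the largest, but a 1.1-fold higher number from compound 2 to compound 3 (0.05 log units; within the scatter) and a 1.3-fold higher number from compound 1 to compound 3 (0.10 log units; within the scatter) both lie within the scatter, so the three compounds cannot be ranked against one another on these data.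

Compound 4, `CCCN1Cc2cc(OCc3cccc(-c4ccc(Cl)c(C(=O)O)c4)c3)ccc2C1=O`, differs from compound 3 in one place: hydrogen in place of methyl on a saturated chain carbon bound to two saturated chain carbons. Among the compounds with values here, no measured step removes a methyl from this chain. Within the data shown here, the steps that bear on it are the exchanges among the groups on the same amide-type nitrogen: a 1.1-fold higher number from compound 1 to compound 2 (0.05 log units; within the scatter), a 1.3-fold higher number from compound 1 to compound 3 (0.10 log units; within the scatter) and a 1.1-fold higher number from compound 2 to compound 3 (0.05 log units; within the scatter). Each of these is within the scatter, so swapping cyclopropylmethyl, cyclobutyl and isobutyl at this position left the number essentially unchanged. On that basis no step beyond the scatter is expected for the shortening to propyl, with at most a slight drift toward a higher number: a 1.2-fold higher number from compound 3 to compound 4 (0.08 log units; within the scatter) is the expected step. Compound 4 is therefore estimated at 120 nM, with a range from 55 nM to 260 nM.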

Compound 4, half-maximal effective concentration: > 10000 nM
Compound 4: a limit, no number (the forecaster's own chance of this, stated with the estimate: 2%); middle value at least 83-fold (1.92 log units) away from the limit.
By their numbers in this assay, from the lowest: compounds 1, 2 and 3 (each within the scatter of the next). At a limit, above all of these: compound 4.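

In this assay, compound 4 gives a limit and not a number: the limit of > 10000 nM in this assay, at which 1 of the 4 values shown sits.

The steps of an at least 100-fold higher number from compound 3 to compound 4 (2.00 log units; beyond the scatter), an at least 110-fold higher number from compound 2 to compound 4 (2.04 log units; beyond the scatter) and an at least 120-fold higher number from compound 1 to compound 4 (2.09 log units; beyond the scatter) are all large and beyond the scatter, whereas the exchanges among cyclopropylmethyl, cyclobutyl and isobutyl stayed within it. The flat picture at this amide-type nitrogen therefore does not extend to propyl, and the loss of a single methyl from the isobutyl chain is enough to break it.

As far as these compounds go, whether a longer chain such as butyl, or a smaller group such as ethyl, would sit with the first three compounds or with compound 4 remains open. What lies behind the step also remains open, and its full size is undefined, with only a lower bound available.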